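A few compounds are considered here, and "the series" means these few. Any claim that something is new, unique, unknown or untested is made for them only; others in the source may bear on it.

Measured so far in an ADME assay on blood (Homo sapiens) for pharmacokinetics; on this read-out lower numbers stand for a shorter-lived compound and higher numbers for a longer-lived compound:

Compound 1, `CC(C)(C)C(=O)OCO[P@@]1(=O)OCC(C)(C)[C@H](C(=O)NCCC(=O)O)O1`, gives > 1 h, a limit of the assay rather than a number.
Compound 2, `CCc1cc(C(=O)OCO[P@@]2(=O)OCC(C)(C)[C@H](C(=O)NCCC(=O)OC)O2)n(C)n1`, gives >= 0.97 h, again a limit rather than a number.
Compound 3, `COC(=O)CCNC(=O)[C@@H]1O[P@](=O)(Oc2ccc(C(F)(F)F)cc2)OCC1(C)C`, gives > 1 h, once more a limit rather than a number.

Compound 2 therefore does not have a settled number in this assay. Its result sits at the limit of >= 0.97 h in this assay, at which 1 of the 3 values shown sits, while the other two compounds sit at the limit of > 1 h in this assay, at which 2 of the 3 values shown sit. Among the measured compounds shown here, all three read-outs are limits, so none of the three compounds can be placed above or below another, and no step between measured compounds can be counted.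

Compound 4, `COC(=O)CCNC(=O)[C@@H]1O[P@@](=O)(OCOC(=O)c2ccnn2C)OCC1(C)C`, has not been measured. It differs from compound 2 in one place: hydrogen in place of ethyl on an aromatic carbon. For the measured compounds named here, with every known value being a limit, there is no measured step to lean on, and the expectation for the step from compound 2 to compound 4 in this assay is none beyond the usual scatter, an expected step that the limit leaves unreadable from compound 2 to compound 4. Compound 4 is accordingly estimated at 1.5 h, with a range from 0.8 h to 3 h, and the assay may well again report only a limit.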

Compound 4, half-life: > 1 h
Compound 4: no number, only a limit; the forecaster's own chance of this, stated with the estimate: 65%; the middle value does not contradict the limit.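

Compound 2 and compound 4 both give limits rather than numbers in this assay, and no step can be read between them for hydrogen in place of ethyl on an aromatic carbon. The compounds shown leave open the actual half-life of each one, and whether that swap changes it at all.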